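Acyl chain length at the acetoxymethyl of compound 1

The source may report more compounds than this note shows. Statements on the series, on what has been measured and on what is new or still open speak of the compounds shown alone.

Compound 1 `CC(=O)OCc1ccc2oc(=O)c(C(=O)Oc3cccc(Br)c3)cc2c1` gives 11.8% in a functional assay on HT-1080 cells (Homo sapiens), read by transwell migration, with a stated time of 24 h, tested at 10 uM (on this read-out lower numbers stand for a stronger effect and higher numbers for a weaker effect at the one concentration tested), and stands lowest of the three numbers in hand. Compound 2 `CC(=O)OCc1ccc2oc(=O)c(C(=O)Sc3cccc(Cl)c3)cc2c1` gives 61.9% and compound 3 `CCCCCC(=O)OCc1ccc2oc(=O)c(C(=O)Oc3cccc(Br)c3)cc2c1` gives 33.9% in this assay. The untested compound 4 `CC(C)C(=O)OCc1ccc2oc(=O)c(C(=O)Oc3cccc(Br)c3)cc2c1` differs from compound 1 by isopropyl in place of methyl on a carbonyl carbon. Of the two measured steps, only a number 22.1 percentage points higher from compound 1 to compound 3 (beyond the scatter) touches the same acyl chain, and it was a modest rise; a number 50.1 percentage points higher from compound 1 to compound 2 (beyond the scatter) concerns the other end of the shared core and does not bear here. Isopropyl is a smaller change than butyl on that chain, so a smaller rise is expected, a number 12.2 percentage points higher from compound 1 to compound 4 (beyond the scatter). For compound 4 the estimate is 24%, within 10% to 42%.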

Compound 4, a percentage reported as activity, at one concentration (the size of the read-out at that concentration, not a potency): 21.1%
Compound 4: the middle estimate sits 2.9 percentage points above what was measured; measured number inside the range.
By their numbers in this assay, from the lowest: compounds 1 and 4 (each within the scatter of the next); then compound 3; then compound 2.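

On this acyl chain, the isopropyl and methyl groups cannot be told apart: a number 9.3 percentage points higher from compound 1 to compound 4 (within the scatter). Shortening the chain from pentyl to isopropyl gives a number 12.8 percentage points lower from compound 3 to compound 4 (beyond the scatter), so the weaker effect of compound 3 does not extend to this branched group. The data offer no explanation for either step.

Still open, from the compounds shown here alone, is whether a straight propyl chain or a cyclohexyl ring on this carbonyl carbon would read like compound 1 or like compound 3. Going by these compounds, an amine-bearing chain at this place also remains open.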